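The source may hold more compounds than are shown below. What is called first, only, known or untested is meant among the compounds shown, and "the series" means these compounds.

Measured so far:
compound 1 `CCCCCCCCNC(=O)/C=C/c1c(/C=C/c2ccc(OC)cc2)cc(OC)cc1OC`: 8660 nM
compound 2 `COc1ccc(/C=C/c2cc(OC)cc(OC)c2/C=C/C(=O)N2CCCC2)cc1`: 6350 nM

In a functional assay on A549 cells (Homo sapiens) for inhibition, read by MTT assay, with a stated time of 48 h (on this read-out higher numbers stand for weaker inhibition and lower numbers for stronger inhibition), compound 2 gives the lower of the two numbers, yet the gap to the other is only a 1.4-fold lower number from compound 1 to compound 2 (0.13 log units; within the scatter), so the two cannot be told apart. Compound 3 `CCCCCCNC(=O)/C=C/c1c(/C=C/c2ccc(OC)cc2)cc(OC)cc1OC` differs from compound 2 at a single spot: hexylamino in place of pyrrolidin-1-yl on a carbonyl carbon. Within the data shown here, the one comparison that bears on this, octylamino giving way to the ring, moved the number a 1.4-fold lower number from compound 1 to compound 2 (0.13 log units; within the scatter), within the scatter. Going back to a straight chain, now hexylamino, is therefore expected to change little. Compound 3 is estimated at 8000 nM, with a range of 4000 nM to 16000 nM. That amounts to an expected step of a 1.3-fold higher number from compound 2 to compound 3 (0.10 log units; within the scatter).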

Compound 3, half-maximal inhibitory concentration: 6230 nM
Beside the measured number, compound 3's estimate is 1.3-fold (0.11 log units) above it, within the range that was stated.
By their numbers in this assay, from the lowest: compounds 3, 2 and 1 (each within the scatter of the next).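

In this assay, replacing the ring with hexylamino, which adds an amide hydrogen, gives a 1.0-fold lower number from compound 2 to compound 3 (0.01 log units; within the scatter), so a ring and an open chain on this carbonyl carbon cannot be told apart. Shortening the chain gives a 1.4-fold lower number from compound 1 to compound 3 (0.14 log units; within the scatter), so octylamino and hexylamino cannot be told apart either, and these three amides form a flat set. Nothing measured here offers an explanation for this flat result. On these data alone, it remains open whether a much shorter chain such as methylamino, a chain ending in an amine, or one ending in a carboxylic acid would shift the number beyond the scatter.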